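Fluoro removal on the sulfonyl aryl ring

The source may report more compounds than this note shows. Statements on the series, on what has been measured and on what is new or still open speak of the compounds shown alone.

Compound 1 `CC1(Cc2ccccc2)CC(S(=O)(=O)c2cccc(F)c2)=C(c2ccc(/C(N)=N\O)cc2)O1` and compound 2 `CC1(Cc2ccccc2)CC(S(=O)(=O)c2c(F)cccc2F)=C(c2ccc(/C(N)=N\O)cc2)O1` differ only on the sulfonyl aryl ring. In an ADME assay on HepG2 cells (Homo sapiens) for cytotoxicity, read by MTT assay, with a stated time of 72 h (a lower number here means that less compound is tolerated, a higher number that more compound is tolerated), compound 1 gives 59600 nM and compound 2 gives 91400 nM; the step of a 1.5-fold higher number from compound 1 to compound 2 (0.19 log units; within the scatter) is within the scatter, so compound 2 stands alongside compound 1 rather than apart from it. Compound 3 `CC1(Cc2ccccc2)CC(S(=O)(=O)c2ccccc2F)=C(c2ccc(/C(N)=N\O)cc2)O1` carries the change (hydrogen in place of fluoro on an aromatic carbon). Among the compounds with values here, the sole step bearing on this change is a 1.5-fold higher number from compound 1 to compound 2 (0.19 log units; within the scatter), and it stays within the scatter. The expected step is therefore small, a 1.3-fold lower number from compound 2 to compound 3 (0.12 log units; within the scatter), with no move beyond the scatter expected. For compound 3 the estimate in this assay is 70000 nM, within a range from 35000 nM to 140000 nM.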

Compound 3, half-maximal cytotoxic concentration: 61700 nM
For compound 3 the middle estimate is 1.1-fold (0.05 log units) above the measured one; the range from low to high includes it.
By their numbers in this assay, from the lowest: compounds 1, 3 and 2 (each within the scatter of the next).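

Hydrogen in place of fluoro on this aromatic carbon gives a 1.5-fold lower number from compound 2 to compound 3 (0.17 log units; within the scatter) in this assay and 2-fluorophenyl in place of 3-fluorophenyl on the sulfonyl sulfur gives a 1.0-fold higher number from compound 1 to compound 3 (0.02 log units; within the scatter) and both steps stay within the scatter. The one-fluoro and two-fluoro rings of compound 1, compound 2 and compound 3 are therefore not separated by this read-out. Nothing available speaks to what lies behind this.

Open, on these data alone, is whether a phenyl with no fluoro on the sulfonyl sulfur stands with these three. Also open, as far as these compounds go, is whether an amine or a carboxylic acid on this ring would give a step beyond the scatter.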